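The source may report more compounds than this note shows. Statements on the series, on what has been measured and on what is new or still open speak of the compounds shown alone.

Measured in a functional assay with Rattus norvegicus as the target; a higher number here means that more compound is needed for the effect, a lower number that less compound is needed:
- compound 1 `CC1(C)C=C(n2ccccc2=O)c2cc(S(=O)(=O)NCCO)ccc2O1`: 1000 nM
- compound 2 `COc1ccc(NS(=O)(=O)c2ccc3c(c2)C(n2ccccc2=O)=CC(C)(C)O3)cc1`: 490 nM
- compound 3 `CC1(C)C=C(n2ccccc2=O)c2cc(S(=O)(=O)Nc3ccc([N+](=O)[O-])cc3)ccc2O1`: 10200 nM

Compound 3 has the highest number of the three, so more of it is needed for the effect than of either other compound. Compound 4 `CC1(C)C=C(n2ccccc2=O)c2cc(S(=O)(=O)N3CCOCC3)ccc2O1` has morpholin-4-yl in place of (4-nitrophenyl)amino on a sulfonyl sulfur.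

Among the compounds with values here, no measured compound carries morpholin-4-yl, so the measured steps offer only a rough guide. The closest evidence comes from the two steps that lead to the 4-nitrophenyl group, read backwards: a 10-fold higher number from compound 1 to compound 3 (1.01 log units; beyond the scatter), and a 21-fold higher number from compound 2 to compound 3 (1.32 log units; beyond the scatter). Both are large. The two compounds without that group are much closer, with a 2.0-fold lower number from compound 1 to compound 2 (0.31 log units; beyond the scatter), a modest step.

In this assay, a large step to a lower number is therefore expected on losing the (4-nitrophenyl)amino group. The expected step is a 6.8-fold lower number from compound 3 to compound 4 (0.83 log units; beyond the scatter). For compound 4 the estimate is 1500 nM, with an expected range of 300 nM to 7000 nM.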

Compound 4, half-maximal effective concentration: 603 nM
Compound 4: middle estimate off by 2.5-fold (0.40 log units), on the high side; measured number inside the range.
By their numbers in this assay, from the lowest: compounds 2, 4 and 1 (each within the scatter of the next, the first and the last beyond it); then compound 3.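

In this assay the sulfonyl sulfur also accepts a saturated ring: morpholin-4-yl has 0 hydrogen-bond donors where (4-nitrophenyl)amino has 1, and the change still gives a 17-fold lower number from compound 3 to compound 4 (1.23 log units; beyond the scatter) as a large step. Compound 4 cannot be told apart from the two other compounds, since a 1.2-fold higher number from compound 2 to compound 4 (0.09 log units; within the scatter) and a 1.7-fold lower number from compound 1 to compound 4 (0.22 log units; within the scatter) are both steps that stay within the scatter. A hydrogen on the sulfonamide nitrogen is therefore not required for a number in this range, and of these four compounds only compound 3 stands clearly apart.

Nothing shown here explains why compound 3 differs from the others. As far as these compounds go, it also remains open whether piperidin-1-yl, which lacks the ring oxygen of morpholin-4-yl, or piperazin-1-yl, which has a ring nitrogen there, would stay close to compound 4.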